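Amine swap on compound 2: expected metabolic stability

This account rests on a few compounds, and the source may have more. Where it says the series, first, only, none or still open, it means among the compounds named here.

Two compounds of this series have numbers in an ADME assay on microsomes from liver (Homo sapiens) for metabolic stability, with a stated time of 30 min, tested at 1 uM; a lower number here means that less of the compound is left, a higher number that more of the compound is left. Compound 1 `CN(Cc1ccc(C2=NCCN2)cc1)C(=O)COCCN(C)S(=O)(=O)c1ccccc1C#N` gives 87%. Compound 2 `COc1cc(C)c(S(=O)(=O)N(C)CCOCC(=O)N2CCN(C3CCN(C4CC4)CC3)CC2)c(C)c1` gives 6%. Compound 2 thus stands lowest of the two, far below compound 1, with a gap that lies beyond the scatter of this assay. The two structures differ in many places at once, so no single change can be tied to that gap.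

Compound 3 `COc1cc(C)c(S(=O)(=O)N(C)CCOCC(=O)N2CCN(CCCN(C)C)CC2)c(C)c1` is the next member, not yet measured. It differs from compound 2 in one place: 3-(dimethylamino)propyl in place of 1-cyclopropylpiperidin-4-yl on an amine nitrogen in a ring. Going by the values given here, no pair of measured compounds differing in a single place exists here, so there is no measured step to calibrate the size of the change. Because compound 2 gives 6% in this assay, little room remains on the downside. The expected step is a number 6 percentage points higher from compound 2 to compound 3 (within the scatter), a small rise that may well stay within the scatter. For compound 3 the estimate in this assay is 12%, with a range from 3% to 35%.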

Compound 3, percent of the compound remaining: 67%
Compound 3: the middle estimate sits 55 percentage points below what was measured, and the stated range ends below it.
By their numbers in this assay, from the lowest: compound 2; then compound 3; then compound 1.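

Putting 3-(dimethylamino)propyl in place of 1-cyclopropylpiperidin-4-yl on an amine nitrogen in a ring gives, in this assay, a number 61 percentage points higher from compound 2 to compound 3 (beyond the scatter), so the series now has a single-place step, and a large one: with the rest of the structure unchanged, the group at this position alone can move the percent of compound remaining by far more than the scatter. The change bundles several differences, since the entering group has no ring while the leaving group has a three-membered ring of carbon only and a six-membered ring with one hetero atom, and the entering group also has fewer heavy atoms. Nothing measured here gives a reason for the step.

As far as these compounds go, it stays open whether the loss of the cyclopropyl, the loss of the six-membered ring or the smaller group size accounts for the step. Nor do the compounds shown tell how the read-out responds to a 1-methylpiperidin-4-yl group, which keeps the six-membered ring without the three-membered ring, or to a longer chain ending in the same dimethylamino group.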